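Halogen swap at the benzylic ring of compound 3

The compounds below may be only part of what the source reports. "The series", "measured", "known", "first", "only" and "open" are said of these compounds alone.

Measured so far:
- compound 1 `CCC1CCN(c2cc(C(F)(F)F)ccc2CNC(=O)C(C)c2ccc(NS(C)(=O)=O)c(F)c2)CC1`: 0.7 nM
- compound 2 `CC(C(=O)NCc1ccc(C(F)(F)F)cc1OC1CCCCC1)c1ccc(NS(C)(=O)=O)c(F)c1`: 0.7 nM
- compound 3 `CC(C(=O)NCc1ccc(C(F)(F)F)cc1F)c1ccc(NS(C)(=O)=O)c(F)c1`: 68.7 nM

All three share one core and are read in an assay on CHO cells for antagonist activity at transient receptor potential cation channel subfamily V member 1 (Homo sapiens), read by FLIPR; a higher number here means a weaker inhibitor, a lower number a stronger inhibitor. Compound 3 gives the highest number of the three in this assay; the other two stand far below it, as the steps of a 98-fold higher number from compound 1 to compound 3 (1.99 log units; beyond the scatter) and a 98-fold higher number from compound 2 to compound 3 (1.99 log units; beyond the scatter) show, both well beyond the scatter. Between compound 1 and compound 2 the step of no change at the digits printed from compound 1 to compound 2 (within the scatter) is flat.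

Compound 4 `CC(C(=O)NCc1ccc(C(F)(F)F)cc1Cl)c1ccc(NS(C)(=O)=O)c(F)c1` is the next analogue. It differs from compound 3 only in chloro in place of fluoro on an aromatic carbon. The measured steps that touch this position, from compound 1 and from compound 2 into compound 3, both exchange a group of several heavy atoms for fluoro; neither tells how one single-atom halogen compares with another at this site. Within the data shown here, since chloro, like fluoro, counts one heavy atom, with no ring, no donor and no acceptor, no step of the size seen in a 98-fold higher number from compound 1 to compound 3 (1.99 log units; beyond the scatter) is expected here. The expectation for compound 4 in this assay is therefore a modest move at most, of the order of a 1.7-fold lower number from compound 3 to compound 4 (0.23 log units; within the scatter), likely toward a lower number but not clearly beyond the scatter. Compound 4 is estimated at 40 nM, with a range from 10 nM to 150 nM.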

Compound 4, inhibition constant: 4 nM
Beside the measured number, compound 4's estimate is 10-fold (1.00 log units) above it, and the stated range ends above it.
By their numbers in this assay, from the lowest: compounds 1 and 2 (each within the scatter of the next); then compound 4; then compound 3.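

In this assay, this aromatic carbon, ortho to a large group and meta to a trifluoromethyl group, responds strongly even to an exchange of one halogen for another: the step is a 17-fold lower number from compound 3 to compound 4 (1.23 log units; beyond the scatter), although the heavy-atom, ring, donor and acceptor counts stay the same. The earlier steps shown here into compound 3 each replaced a group of several heavy atoms, so a large group appeared to be what set the level at this site, but the single chlorine closes much of that gap, leaving a 5.7-fold higher number from compound 2 to compound 4 (0.76 log units; beyond the scatter) and a 5.7-fold higher number from compound 1 to compound 4 (0.76 log units; beyond the scatter) as the remaining modest steps. No measurement available here accounts for the difference between fluoro and chloro at this position.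

Open, going by these compounds, is whether a bromo or a methyl on this carbon would stand with chloro or come closer to the cyclohexyloxy and 4-ethylpiperidin-1-yl compounds, and whether a methoxy would keep the level of compound 2 without its ring. Also open, on these data alone, is whether the step from fluoro to chloro would hold with a tert-butyl group in place of the trifluoromethyl group.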